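A few compounds are considered here, and "the series" means these few. Any claim that something is new, unique, unknown or untested is made for them only; others in the source may bear on it.

Compound 1 `O=C(Nc1cccc(-n2cc(-c3ccncc3)c(-c3cc(O)cc(Cl)c3)n2)c1)Nc1ccc(Cl)c(C(F)(F)F)c1` in a functional assay on HCT-116 cells (Homo sapiens) for inhibition, read by sulforhodamine B assay, with a stated time of 48 h, tested at 0.01 uM (a higher number here means a weaker effect of the compound at the concentration tested, a lower number a stronger effect), gives 104%, the larger of the two numbers shown, though its gap to compound 2 `O=C(Nc1cccc(-n2cc(-c3ccncc3)c(-c3cc(O)cc(Cl)c3)n2)c1)Nc1ccc(Cl)c(Cl)c1`, which gives 101%, is within the scatter: a number 3 percentage points lower from compound 1 to compound 2 (within the scatter). Compound 3 `COc1cc(Cl)cc(-c2nn(-c3cccc(NC(=O)Nc4ccc(Cl)c(C(F)(F)F)c4)c3)cc2-c2ccncc2)c1` differs from compound 1 by methyl in place of hydrogen on an oxygen on an aromatic ring. Among the measured compounds shown here, no measured step touches this oxygen; the one step known, from compound 1 to compound 2, sits elsewhere and stayed within scatter, so both measured numbers simply show no effect at this concentration. For compound 3 no step beyond the scatter is expected, a number 2 percentage points lower from compound 1 to compound 3 (within the scatter). Compound 3 is estimated at 102%, between 90% and 114%.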

Compound 3, a percentage reported as activity, at one concentration (the size of the read-out at that concentration, not a potency): 104%
Estimate against measurement, compound 3: 2 percentage points below; low and high end bracket the measured number.
By their numbers in this assay, from the lowest: compounds 2, 1 and 3 (each within the scatter of the next).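

In this assay, among the compounds shown here, hydroxy to methoxy on the aromatic ring gives no change at the digits printed from compound 1 to compound 3 (within the scatter), the only reading so far at this oxygen. At this concentration the hydrogen on this oxygen can be replaced by methyl with no visible consequence, yet all three compounds show no effect, so this test cannot tell whether the position matters at all. Nothing available bears on why the reading stays flat.

Still open, from the compounds shown here alone, is whether an amine in place of the hydroxy, or a longer chain such as ethoxy on this oxygen, would read differently. Also open, going by these compounds, is whether hydroxy and methoxy would separate at a concentration where the series shows an effect.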